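Branched alkyl carbonyl in place of a thiophene carbonyl

The source may report more compounds than this note shows. Statements on the series, on what has been measured and on what is new or still open speak of the compounds shown alone.

In an assay on isolated protein for inhibition of NAD-dependent protein deacylase sirtuin-6 (Homo sapiens), read by fluorescence, tested at 200 uM (on this read-out lower numbers stand for less inhibition and higher numbers for more inhibition at the one concentration tested (going by the name of the read-out)), compound 1 `CCC(=O)Nc1ccc(C(=O)Nc2ccc(C(=O)O)c(O)c2)cc1` gives 70%, while compound 2 `O=C(O)c1cccc(NC(=O)c2cccc(NC(=O)c3cccs3)c2)c1` gives 39%. Compound 2 therefore stands lowest of the two numbers, and compound 1 sits higher by a gap beyond the usual scatter. Within the data shown here, the two compounds differ in more than one place, so their values show only that compound 1 inhibits more strongly at the single concentration tested. Compound 3 `CCC(CC)C(=O)Nc1cccc(C(=O)Nc2cccc(C(=O)O)c2)c1` arises from compound 2 by one change, (pentan-3-yl in place of thiophen-2-yl on a carbonyl carbon). Among the measured compounds shown here, no measured pair carries exactly this exchange, so the expectation for compound 3 rests on the two values alone and is uncertain. The expected step, a number 6 percentage points higher from compound 2 to compound 3 (within the scatter), is small and upward, and it may well stay within the scatter. In this assay compound 3 is estimated at 45%, with a range from 20% to 70%.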

Compound 3, a percentage reported as inhibition, at one concentration (the size of the read-out at that concentration, not a potency): 54%
Compound 3: the middle estimate sits 9 percentage points below what was measured; the measured number falls inside the stated range.
By their numbers in this assay, from the lowest: compound 2; then compound 3; then compound 1.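

In this assay, replacing thiophen-2-yl with pentan-3-yl on a carbonyl carbon whose other neighbour is an amide-type nitrogen gives a number 15 percentage points higher from compound 2 to compound 3 (beyond the scatter). This position therefore responds to the group it carries, and the five-membered aromatic ring with its sulfur and its hydrogen-bond acceptor can give way to a ringless group of the same heavy-atom count without a loss of inhibition at the one concentration tested. Nothing available accounts for this step.

From the compounds shown here alone, what a straight pentyl chain or a cyclopentyl ring would give on the same carbonyl carbon stays open, and with it whether the branching or the absence of the aromatic ring goes with the higher number. Compound 1 differs from compound 3 in more than one place, so the pair cannot show which difference goes with its number.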